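Anilide swap on a shared piperazine-phthalazine core

This account rests on a few compounds, and the source may have more. Where it says the series, first, only, none or still open, it means among the compounds named here.

Measured compounds:
compound 1 `COc1ccc(NC(=O)CN2CCN(c3nnc(Cc4ccncc4)c4ccccc34)CC2)cc1OC` — 40100 nM
compound 2 `Cc1ccc(F)cc1NC(=O)CN1CCN(c2nnc(Cc3ccccc3)c3ccccc23)CC1` — 171000 nM

In a functional assay on HT-29 cells (Homo sapiens) for cytotoxicity, read by MTT assay, with a stated time of 72 h (on this read-out higher numbers stand for weaker inhibition and lower numbers for stronger inhibition), compound 1 gives 40100 nM, the lower of the two numbers recorded. Compound 2, which differs from it in several places, gives 171000 nM in this assay, a gap that lies beyond the usual scatter. Among the measured compounds shown here, no pair of measured compounds differs in only one place, so no single step can be read from them.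

Compound 3 `O=C(CN1CCN(c2nnc(Cc3ccncc3)c3ccccc23)CC1)Nc1cc(C(F)(F)F)ccc1Cl` is not yet measured. It differs from compound 1 in one place: 2-chloro-5-(trifluoromethyl)phenyl in place of 3,4-dimethoxyphenyl on an amide-type nitrogen. The two measured compounds offer no guide to what this particular exchange does, since the anilide change in compound 2 comes together with a change elsewhere. The step is therefore expected to be small, with no clear direction beyond the scatter, and compound 3 is estimated at 35000 nM (range 9000 nM to 130000 nM), meaning an expected step of a 1.1-fold lower number from compound 1 to compound 3 (0.06 log units; within the scatter).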

Compound 3, half-maximal inhibitory concentration: 4810 nM
Estimate against measurement, compound 3: 7.3-fold (0.86 log units) above, outside the stated range (below it).
By their numbers in this assay, from the lowest: compound 3; then compound 1; then compound 2.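

In this assay the group on the amide-type nitrogen turns out to matter: 2-chloro-5-(trifluoromethyl)phenyl in place of 3,4-dimethoxyphenyl gives an 8.3-fold lower number from compound 1 to compound 3 (0.92 log units; beyond the scatter) with the rest of the molecule unchanged. Among the compounds shown here, this is the only single-place change that can be read here, and it shows that the anilide part alone can move the number beyond the scatter. Nothing available accounts for the size of this step.

From the compounds shown here alone, the exchange replaces the whole substituted ring at once, so the shares of the chlorine and the trifluoromethyl group cannot be separated, and whether a nitrile or a carboxylic acid in this part of the molecule would follow the same direction remains open. For the compounds shown here, compound 2 differs from the other two compounds in several places, so no step to it can be read.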